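Methoxymethyl Ether to Ester on a Shared Core

A few compounds are considered here, and "the series" means these few. Any claim that something is new, unique, unknown or untested is made for them only; others in the source may bear on it.

Measured compounds in a functional assay on the whole organism with Rattus norvegicus as the target, with a stated time of 4 h, at a dose of 40 mg/kg by the intraperitoneal route; a higher number here means more inhibition at the dose given (going by the name of the read-out), a lower number less inhibition:
compound 1, `Cc1nc2c(CSc3ccccc3)cccn2c1C`, gives 29%
compound 2, `Cc1nc2c(C[S+]([O-])c3ccccc3)cccn2c1C`, gives 42%
compound 3, `COCc1c(C)nc2c(OCc3ccccc3)cccn12`, gives 99%

Compound 3 stands highest of the three in this assay, beyond the scatter above both compound 2 and compound 1. The next compound, compound 4 with structure `CCCCC(=O)OCc1c(C)nc2c(OCc3ccccc3)cccn12`, differs from compound 3 in one place: butylcarbonyl in place of methyl on an oxygen on a saturated carbon. Going by the values given here, no pair of measured compounds shows this kind of change, so its effect is unknown. Because compound 3 gives 99%, the highest number of the three, the expected step of a number 14 percentage points lower from compound 3 to compound 4 (beyond the scatter) is a modest drop that may still lie within the scatter. Compound 4 is estimated at 85%, with a range from 55% to 100%.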

Compound 4, a percentage reported as inhibition, in the whole organism at one dose (the size of the read-out at that dose, not a potency): 45%
Compound 4: the middle estimate sits 40 percentage points above what was measured; the measured number lies below the stated range.
By their numbers in this assay, from the lowest: compound 1; then compounds 2 and 4 (each within the scatter of the next); then compound 3.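

Putting butylcarbonyl in place of methyl on this oxygen gives a number 54 percentage points lower from compound 3 to compound 4 (beyond the scatter) in this assay and shows that the read-out depends strongly on what this oxygen carries. Going by these compounds alone, the earlier compounds offered no matched pair, so this is the first sign that the position is sensitive to change. Nothing available here explains the size of this loss.

From the compounds shown here alone, the carbonyl and the longer chain enter together, so their separate contributions remain open. A butyl ether or a small acetyl ester on the same oxygen would help tell them apart.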